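Naphthalene sulfonamides: pentylamino versus phenylthioureido substituent

A few compounds are considered here, and "the series" means these few. Any claim that something is new, unique, unknown or untested is made for them only; others in the source may bear on it.

Measured so far in an assay on VSM-A10 cells for antagonist activity at Endothelin-1 receptor (Rattus norvegicus); a lower number here means a stronger inhibitor, a higher number a weaker inhibitor:
- compound 1, `CCCCCNc1cccc2c(S(=O)(=O)Nc3onc(C)c3C)cccc12`: 80 nM
- compound 2, `Cc1noc(NS(=O)(=O)c2ccc(N/C(S)=N/c3ccccc3)cc2)c1C`: 4100 nM
- compound 3, `CN(C)c1cccc2c(S(=O)(=O)Nc3onc4c3CCCC4)cccc12`: 153000 nM

Compound 1 gives the lowest number of the three. Compound 2 is its nearest neighbour, and the gap between them is beyond the scatter; compound 3 is furthest away, also beyond the scatter. Compound 2 carries the thioureido group on a simpler core than compound 1, and compound 3 carries a dimethylamino group on the shared core of compound 1 together with a different heterocycle on the sulfonamide, so no single-point comparison is available among the measured compounds.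

Compound 4, `Cc1noc(NS(=O)(=O)c2cccc3c(N/C(S)=N/c4ccccc4)cccc23)c1C`, is the untested member. For the measured compounds named here, it differs from compound 1 in one place: a group of 9 heavy atoms (7 carbon, 1 nitrogen, 1 sulfur; one six-membered aromatic ring of carbon only) in place of a group of 5 heavy atoms (5 carbon; no ring), on a nitrogen on an aromatic ring The entering group is the one that compound 2 carries, where compound 2 gives 4100 nM; compound 4 keeps the core of compound 1, and no measured pair shows what this group does on that core.

In this assay compound 4 is expected to give 500 nM, in the range 80 nM to 4000 nM. The step of a 6.3-fold higher number from compound 1 to compound 4 (0.80 log units; beyond the scatter) is expected to run toward a higher number, probably beyond the scatter, with wide uncertainty.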

Compound 4, half-maximal inhibitory concentration: 150 nM
Beside the measured number, compound 4's estimate is 3.3-fold (0.52 log units) above it; the range from low to high includes it.
By their numbers in this assay, from the lowest: compounds 1 and 4 (each within the scatter of the next); then compound 2; then compound 3.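

In this assay, the step of a 1.9-fold higher number from compound 1 to compound 4 (0.27 log units; within the scatter) lies within the scatter, so on the shared core this nitrogen on an aromatic ring carries either the pentyl group or the thioureido group with its six-membered aromatic ring, and the two compounds cannot be told apart. For the compounds shown here, until now the thioureido group had been seen only on the simpler core of compound 2, so this is the first reading of it on the core of compound 1, and it shows that replacing an open chain with no ring by a larger ring-bearing group, which brings a hydrogen-bond donor and acceptor, leaves the number within the scatter here. Nothing available explains this result.

Still open, going by these compounds, is whether the same holds for other groups on this nitrogen, such as a shorter propyl chain, a longer octyl chain, a benzyl group or a chain ending in a carboxylic acid. Compound 3 differs from compound 1 in two places, and the compounds shown do not separate the contribution of its dimethylamino group from that of the different heterocycle on the sulfonamide.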